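Chlorinated purine amides in the tail flick test

This account rests on a few compounds, and the source may have more. Where it says the series, first, only, none or still open, it means among the compounds named here.

Measured so far:
compound 1 `CC(C)[C@H](NC(=O)CN(c1nc(Cl)nc2[nH]cnc12)C1CC1)C(=O)OCc1ccccc1` gives 55.5%
compound 2 `NCCCC[C@H](NC(=O)CN(c1nc(Cl)nc2[nH]cnc12)C1CC1)C(=O)OCc1ccccc1` gives 41.2%
compound 3 `NCCCC[C@H](NC(=O)CN(c1nc(Cl)nc2[nH]cnc12)C1CC1)C(=O)O` gives 53.8%

These numbers come from a functional assay on the whole organism (Tail, strain ICR) with Mus musculus as the target, in the tail flick test, with a stated time of 60 min, at a dose of 25 umol/kg by the oral route; on this read-out higher numbers stand for a stronger effect at the one dose given and lower numbers for a weaker effect. Compound 4 `CC(C)[C@H](NC(=O)CN(c1nc(Cl)nc2[nH]cnc12)C1CC1)C(=O)O` has not yet been measured in this assay.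

Two changes are shown. The first, (isopropyl in place of 4-aminobutyl on a saturated chain carbon bound to an amide-type nitrogen and a carbonyl carbon), gave a number 14.3 percentage points higher from compound 2 to compound 1 (beyond the scatter). The second, which separates the cores of compound 2 and compound 3, is hydrogen in place of benzyl on an oxygen next to a carbonyl group, and it gave a number 12.6 percentage points higher from compound 2 to compound 3 (beyond the scatter).

Compound 4 arises from compound 3 by isopropyl in place of 4-aminobutyl on a saturated chain carbon bound to an amide-type nitrogen and a carbonyl carbon. The place of this change is described in exactly the same words as for the change from compound 2 to compound 1, so it counts as the same change, now made on the core of compound 3 rather than that of compound 2. Setting the expected step beside the earlier one, the step from compound 3 to compound 4 is estimated at a number 10.2 percentage points higher from compound 3 to compound 4 (beyond the scatter), resting on compound 2 and compound 1, whose step was a number 14.3 percentage points higher from compound 2 to compound 1 (beyond the scatter). Compound 4 is therefore expected to reach about 64%, most likely between 49% and 79%.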

Compound 4, a percentage reported as activity, at one dose (the size of the read-out at that dose, not a potency): 38.8%
Beside the measured number, compound 4's estimate is 25.2 percentage points above it; the measured number lies below the stated range.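

In this assay, isopropyl in place of 4-aminobutyl does not carry over from one core to the other, since on the core of compound 3 it gives a number 15 percentage points lower from compound 3 to compound 4 (beyond the scatter), and the same change on the two cores points in opposite directions: the same change on two cores in this assay, a number 14.3 percentage points higher (beyond the scatter) from compound 2 to compound 1 and a number 15 percentage points lower (beyond the scatter) from compound 3 to compound 4, 29.3 percentage points apart, beyond the scatter of two such steps. Hydrogen in place of benzyl on an oxygen next to a carbonyl group also reverses, now giving a number 16.7 percentage points lower from compound 1 to compound 4 (beyond the scatter), so neither change has a fixed effect here and each depends on the group present at the other place: the same change on two cores in this assay, a number 12.6 percentage points higher (beyond the scatter) from compound 2 to compound 3 and a number 16.7 percentage points lower (beyond the scatter) from compound 1 to compound 4, 29.3 percentage points apart, beyond the scatter of two such steps. This shows that, among these four compounds, a step measured on one core is a poor guide to the same step on another, but it does not show why, and it cannot be extended beyond these compounds, this dose and this time point.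

The compounds shown leave open how a shorter amine chain, such as 3-aminopropyl, would behave on either core. They also leave open whether a methyl ester would follow the benzyl ester or the free acid.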